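The compounds below may be only part of what the source reports. "The series", "measured", "known", "first", "only" and "open" are said of these compounds alone.

Of the compounds shown here, three have numbers so far in a functional assay on RAW264.7 cells (Mus musculus), read by luminescence, with a stated time of 24 h (a higher number here means that more compound is needed for the effect, a lower number that less compound is needed), and the account starts from compound 3 `CC(C)C[C@@H](/C=C/C(C)(C)C(=O)NC1CC(C)(C)NC(C)(C)C1)NC(=O)OC(C)(C)C` which gives 1150 nM as its half-maximal effective concentration. Compound 1 `CC(C)C[C@@H](/C=C/C1(C(=O)NC2CC(C)(C)NC(C)(C)C2)CC1)NC(=O)OC(C)(C)C` gives 1130 nM and so sits level with compound 3 within the scatter. Compound 2 `CC1(C)CC(NC(=O)C(/C=C/[C@H](NC(=O)OC(C)(C)C)c2ccc(F)cc2)(Cc2ccc(F)cc2)Cc2ccc(F)cc2)CC(C)(C)N1` gives 250 nM which is a lower number than that of compound 3 by a margin beyond the scatter. Compound 3 therefore stands at the upper end of this small set, together with compound 1.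

The next compound is compound 4 `CC(C)C[C@H](/C=C/C(C)(C)C(=O)NC1CC(C)(C)NC(C)(C)C1)NC(=O)OC(C)(C)C` and the change from compound 3 is the two compounds have the same atoms and bonds and differ only in configuration as drawn: 1 of 2 stereo elements differ; a stereocentre at a saturated chain carbon is drawn S in compound 3 and R in compound 4 with nothing leaving and nothing entering: a stereocentre at a saturated chain carbon is drawn S in compound 3 and R in compound 4. Within the data shown here, no measured pair isolates a change of configuration, so the data give no direction for such a step. The expectation therefore stays close to compound 3 at 1150 nM with no step beyond the scatter foreseen, though the uncertainty is wide on both sides. The estimated change a 1.1-fold higher number from compound 3 to compound 4 (0.05 log units; within the scatter) is expected to stay within the scatter. For compound 4 the expected value is 1300 nM with an estimated range from 450 nM to 3800 nM in this assay once it is measured.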

Compound 4, half-maximal effective concentration in the RAW264.7 assay: 1170 nM
Compound 4: the middle estimate sits 1.1-fold (0.05 log units) above what was measured; low and high end bracket the measured number.
By their numbers in the RAW264.7 assay, from the lowest: compound 2; then compounds 1, 3 and 4 (each within the scatter of the next).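

Among these compounds, in the RAW264.7 assay, turning the stereocentre at the saturated chain carbon from S to R gives a 1.0-fold higher number from compound 3 to compound 4 (0.01 log units; within the scatter), and this is the first measured pair to isolate a change of configuration. At this position, with these groups around it, the configuration as drawn therefore makes no difference that the assay can resolve, and the same holds in a physicochemical assay for lipophilicity (on this read-out lower numbers stand for lower lipophilicity and higher numbers for higher lipophilicity), where the change gives no change at the digits printed from compound 3 to compound 4 (within the scatter). In the physicochemical assay compound 3 gives 4 and compound 4 gives 4. The comparison can be read directly as one of configuration, because nothing else separates the pair: the fact that compounds 3 and 4 differ only in the configuration as drawn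

The compounds shown leave open whether configuration at this carbon stays without consequence when the group it carries changes, for instance to a longer chain or to one ending in a primary amine, since the only pair that tests configuration carries a single set of groups. They also leave open whether the same would hold if the carbamate on that carbon gave way to a free amine or a carboxylic acid, and the data give no direction for either case.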